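The source may report more compounds than this note shows. Statements on the series, on what has been measured and on what is new or still open speak of the compounds shown alone.

Working notes on the series. Compound 3 `Brc1ccc(-c2cn3ccnc3c(-c3ccc4ncn(C5CCCCC5)c4c3)n2)cc1` carries a 4-bromophenyl on the shared core; in a functional assay on HL-60 cells (Homo sapiens) for inhibition, read by sulforhodamine B assay, with a stated time of 48 h, tested at 10 uM (on this read-out lower numbers stand for less inhibition and higher numbers for more inhibition at the one concentration tested (going by the name of the read-out)), compound 3 gives 23.2%. That places it second of the three measured numbers. The methoxy analogue compound 1 `COc1ccc(-c2cn3ccnc3c(-c3ccc4ncn(C5CCCCC5)c4c3)n2)cc1` gives 98.6%, and the fluoro analogue compound 2 `Fc1ccc(-c2cn3ccnc3c(-c3ccc4ncn(C5CCCCC5)c4c3)n2)cc1` gives 2.03%. The steps arriving at compound 3 are a number 75.4 percentage points lower from compound 1 to compound 3 (beyond the scatter) and a number 21.2 percentage points higher from compound 2 to compound 3 (beyond the scatter).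

Compound 4 `FC(F)(F)c1cccc(-c2cn3ccnc3c(-c3ccc4ncn(C5CCCCC5)c4c3)n2)c1` is the unmeasured analogue: 3-(trifluoromethyl)phenyl in place of 4-bromophenyl on an aromatic carbon. Within the data shown here, no measured step covers a trifluoromethyl group or a phenyl substituted in the 3-position, so the change has no direct precedent here. What bears on it is that both halogen-bearing phenyls sit far below the methoxy compound, as shown by a number 96.6 percentage points lower from compound 1 to compound 2 (beyond the scatter) and a number 75.4 percentage points lower from compound 1 to compound 3 (beyond the scatter), while the swap between the two halogens, a number 21.2 percentage points higher from compound 2 to compound 3 (beyond the scatter), shifted the read-out only modestly. A fluorine-containing group entering in place of bromine is therefore expected to keep inhibition in the low range rather than return it toward the level of compound 1. For compound 4 the expected step is a number 8.2 percentage points lower from compound 3 to compound 4 (within the scatter), a small move downward or none beyond the scatter. The estimate for compound 4 in this assay is 15%, with a range from 0% to 45%.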

Compound 4, a percentage reported as inhibition, at one concentration (the size of the read-out at that concentration, not a potency): 1.06%
Beside the measured number, compound 4's estimate is 13.9 percentage points above it; the measured number falls inside the stated range.
By their numbers in this assay, from the lowest: compounds 4 and 2 (each within the scatter of the next); then compound 3; then compound 1.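

In this assay, the 3-(trifluoromethyl)phenyl group brings a second substituted phenyl into the lowest part of the range: a number 1 percentage points lower from compound 2 to compound 4 (within the scatter) leaves it indistinguishable from the 4-fluorophenyl of compound 2, while a number 22.1 percentage points lower from compound 3 to compound 4 (beyond the scatter) shows that the 4-bromophenyl of compound 3 retains a measurable margin over it. The gap to the 4-methoxyphenyl remains very wide, at a number 97.5 percentage points lower from compound 1 to compound 4 (beyond the scatter), so a change in both the group and its place on the phenyl ring does not recover the high read-out, and among these four compounds only compound 1 reaches it. No measured information available here accounts for these differences.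

Compound 4 differs from the other compounds in both the identity of the substituent and its place on the phenyl ring, so the compounds shown leave open how much of the step from compound 3 belongs to the trifluoromethyl group and how much to its place. They also leave open whether the high read-out of compound 1 is specific to methoxy or extends to an ethoxy group, a hydroxyl or a dimethylamino group on the same phenyl.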